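From Compound 1 to Compound 3: One Benzyl Group Exchanged

The compounds below may be only part of what the source reports. "The series", "measured", "known", "first", "only" and "open" are said of these compounds alone.

Within the data shown here, compound 1 `C=CC1=C(C(=O)NCc2ccc(C)cc2)C(c2ccc(OC)cc2)OC1` is the only compound here with a definite number in a functional assay on HeLa cells (Homo sapiens) for cytotoxicity, read by MTT assay, with a stated time of 24 h (on this read-out lower numbers stand for stronger inhibition and higher numbers for weaker inhibition), where compound 1 gives 15900 nM. Its partner compound 2 `C=CC1=C(C(=O)NCc2ccc(C)cc2)C(c2ccc(OC)c(OC)c2)OC1` carries one more methoxy on an aromatic carbon. In this assay compound 2 gives > 100000 nM, which is a limit of the assay and not a number. From the compounds shown here alone, the step of an at least 6.2-fold higher number from compound 1 to compound 2 (0.79 log units; beyond the scatter) therefore rests on (the limit of > 100000 nM in this assay, at which 1 of the 2 values shown sits), and its true size is unknown.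

Compound 3 `C=CC1=C(C(=O)NCc2ccccc2F)C(c2ccc(OC)cc2)OC1` differs from compound 1 at another place: 2-fluorophenyl in place of 4-methylphenyl on a saturated chain carbon bound to an amide-type nitrogen. Among the measured compounds shown here, no measured step touches this part of the molecule; the single step known concerns a methoxy on an aromatic carbon elsewhere in the shared core, and it gives no guidance for a change on the saturated chain carbon bound to the amide-type nitrogen. With nothing pointing either way, the expected step from compound 1 to compound 3 in this assay is a 1.0-fold higher number from compound 1 to compound 3 (0.00 log units; within the scatter), that is, none beyond the scatter. Compound 3 is therefore expected to give about 16000 nM in this assay, with a range from 5000 nM to 50000 nM.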

Compound 3, half-maximal inhibitory concentration: > 100000 nM
Compound 3 gave a limit, no number; the forecaster's own chance of this, stated with the estimate: 10%; middle value at least 6.2-fold (0.79 log units) away from the limit.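

Until now, only a methoxy on an aromatic carbon had been seen to matter, and this result shows that the place on a saturated chain carbon bound to an amide-type nitrogen also responds: putting 2-fluorophenyl in place of 4-methylphenyl there gives an at least 6.2-fold higher number from compound 1 to compound 3 (0.79 log units; beyond the scatter) in this assay. Compound 3 gives > 100000 nM, which is a limit of the assay and not a number. From the compounds shown here alone, the change from 4-methylbenzyl to 2-fluorobenzyl therefore clearly weakens the read-out, but the true size of the step is unknown, and the comparison rests on a limit shared with compound 2: the limit of > 100000 nM in this assay, at which 2 of the 3 values shown sit.

The exchange removes a methyl and adds a fluorine in a single step, so the compounds shown cannot tell whether the loss of one or the arrival of the other accounts for the result. They also leave open how this place would respond to a plain benzyl group, which carries neither, or to a longer chain such as 2-phenylethyl, and whether either would keep a measurable number in this assay.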